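Moving two methyl groups on the aromatic ring

The source may hold more compounds than are shown below. What is called first, only, known or untested is meant among the compounds shown, and "the series" means these compounds.

Measured so far:
- compound 1 `COC1=C(C)C(=O)/C(=C(O)/C=C/c2cccc(OC)c2)C(=O)C1(C)C`: 3.3 ug/mL
- compound 2 `COC1=C(C)C(=O)/C(=C(O)/C=C/c2c(C)cccc2C)C(=O)C1(C)C`: 7.1 ug/mL

In a functional assay on KB cells (Homo sapiens) for cytotoxicity (on this read-out lower numbers stand for an effect already at smaller amounts and higher numbers for an effect only at larger amounts of compound), compound 2 has the higher of the two numbers, at 7.1 ug/mL. For the measured compounds named here, the only measured step is a 2.2-fold higher number from compound 1 to compound 2 (0.33 log units; beyond the scatter). It places 2,6-dimethylphenyl where 3-methoxyphenyl stood, and it is modest but beyond the usual scatter.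

The next compound is compound 3 `COC1=C(C)C(=O)/C(=C(O)/C=C/c2cc(C)cc(C)c2)C(=O)C1(C)C`, and the change is 3,5-dimethylphenyl in place of 2,6-dimethylphenyl on a double-bonded chain carbon bound to a double-bonded chain carbon. Compound 3 has the same atoms as compound 2, joined differently. Its 3,5-dimethylphenyl name is closer to the 3-methoxyphenyl of compound 1, which gives 3.3 ug/mL. A modest move back towards that number is therefore expected, though this single comparison is thin support. The expected change is a 1.6-fold lower number from compound 2 to compound 3 (0.20 log units; within the scatter). Compound 3 is estimated at 4.5 ug/mL, with an expected range of 1.8 ug/mL to 11 ug/mL.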

Compound 3, concentration for half-maximal effect: 3.1 ug/mL
Compound 3: the middle estimate sits 1.5-fold (0.16 log units) above what was measured; the measured number falls inside the stated range.
By their numbers in this assay, from the lowest: compounds 3 and 1 (each within the scatter of the next); then compound 2.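

In this assay, moving the two methyl groups around the aromatic ring, from 2,6-dimethylphenyl to 3,5-dimethylphenyl, gives a 2.3-fold lower number from compound 2 to compound 3 (0.36 log units; beyond the scatter), so this position responds to how the atoms of a group are arranged, even when the atoms themselves stay the same. For the compounds shown here, the other comparison, a 1.1-fold lower number from compound 1 to compound 3 (0.03 log units; within the scatter), shows that 3,5-dimethylphenyl and 3-methoxyphenyl cannot be told apart here, which leaves 2,6-dimethylphenyl as the only one of the three groups standing apart from the others. Nothing available here explains why the arrangement matters.

On these data alone, all three compounds carry only methyl or methoxy groups on this aromatic ring, so it remains open what an amine or a carboxylic acid there would do. Also open, as far as these compounds go, is whether a single methyl group would behave like either pair.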